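A Cyclohexyl Ring Replaces the Aminopropyl Chain

A few compounds are considered here, and "the series" means these few. Any claim that something is new, unique, unknown or untested is made for them only; others in the source may bear on it.

Of the compounds shown here, three sharing one core have been tested in a functional assay on HCT-116 cells (Homo sapiens) for cytotoxicity, read by MTT assay, with a stated time of 72 h; a higher number here means a weaker inhibitor, a lower number a stronger inhibitor. Going by the values given here, compound 2 `NCCCNc1c(C(=O)NCc2ccc(F)cc2)nc(Br)c2cccnc12` gives 18000 nM, the only actual number among them. For compound 1 `O=C(NCc1ccc(F)cc1)c1nc(Br)c2cccnc2c1NCCCNc1c(C(=O)NCc2ccc(F)cc2)nc(Br)c2cccnc12` the result is a limit, > 20000 nM. For compound 3 `CC(C)(C)OC(=O)N1CCN(c2c(C(=O)NCc3ccc(F)cc3)nc(Br)c3cccnc23)CC1` the result is also a limit, > 10000 nM. Compound 4 `N[C@H]1CC[C@H](Nc2c(C(=O)NCc3ccc(F)cc3)nc(Br)c3cccnc23)CC1` keeps the core of compound 2 but carries 4-aminocyclohexyl in place of 3-aminopropyl on a nitrogen on an aromatic ring. Among the compounds with values here, no measured pair shows this change, so only a small shift toward a lower number in this assay is expected, possibly none beyond the scatter. The estimated step is a 1.5-fold lower number from compound 2 to compound 4 (0.18 log units; within the scatter). Compound 4 is estimated at 12000 nM, with an expected range of 4000 nM to 30000 nM.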

Compound 4, half-maximal inhibitory concentration: 4000 nM
Compound 4: the middle estimate sits 3.0-fold (0.48 log units) above what was measured; the range from low to high includes it.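

Going by these compounds alone, until now compound 2 held the only actual number, so nothing showed whether this position could respond to a change at all. In this assay, replacing 3-aminopropyl with 4-aminocyclohexyl on the aromatic-ring nitrogen gives a 4.5-fold lower number from compound 2 to compound 4 (0.65 log units; beyond the scatter), so the position does respond, with the terminal amine kept. Nothing shown accounts for this shift. As far as these compounds go, it remains open whether the ring itself or its two defined stereocentres carry the step, and how a piperidine or a longer chain ending in an amine would compare.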